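Swapping chloro for cyano on the sulfonyl aryl ring

The source may report more compounds than this note shows. Statements on the series, on what has been measured and on what is new or still open speak of the compounds shown alone.

Measured in a functional assay on QGY-7703 cells (Homo sapiens) for cytotoxicity, read by MTT assay, with a stated time of 24 h; a lower number here means a stronger inhibitor, a higher number a weaker inhibitor:
- compound 1 `Cc1ccc(S(=O)(=O)N2C/C(=C\c3cccnc3)C(=O)/C(=C/c3ccccc3C(F)(F)F)C2)cc1`: 6170 nM
- compound 2 `O=C1/C(=C/c2cccnc2)CN(S(=O)(=O)c2ccc([N+](=O)[O-])cc2)C/C1=C\c1ccccc1C(F)(F)F`: 7660 nM
- compound 3 `O=C1/C(=C/c2cccnc2)CN(S(=O)(=O)c2ccc(Cl)cc2)C/C1=C\c1ccccc1C(F)(F)F`: 3440 nM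

Two measured steps place compound 3: a 1.8-fold lower number from compound 1 to compound 3 (0.25 log units; within the scatter), and a 2.2-fold lower number from compound 2 to compound 3 (0.35 log units; beyond the scatter). The next structure, compound 4 `N#Cc1ccc(S(=O)(=O)N2C/C(=C\c3cccnc3)C(=O)/C(=C/c3ccccc3C(F)(F)F)C2)cc1`, keeps the shared core and changes one group: cyano in place of chloro on an aromatic carbon. This is cyano in place of chloro on an aromatic carbon, para to a large group. The same place also gave a 1.2-fold higher number from compound 1 to compound 2 (0.09 log units; within the scatter). All three steps are small, so no step beyond the scatter is expected in this assay. The expected change is a 1.6-fold higher number from compound 3 to compound 4 (0.20 log units; within the scatter). Compound 4 is expected at 5500 nM, with an estimated range of 2800 nM to 10500 nM.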

Compound 4, half-maximal inhibitory concentration: 6150 nM
For compound 4 the middle estimate is 1.1-fold (0.05 log units) below the measured one, within the range that was stated.
By their numbers in this assay, from the lowest: compounds 3, 4, 1 and 2 (each within the scatter of the next, the first and the last beyond it).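

In this assay, the 4-cyanophenyl group sits within the scatter of all three others at this place: a 1.8-fold higher number from compound 3 to compound 4 (0.25 log units; within the scatter) and a 1.2-fold lower number from compound 2 to compound 4 (0.10 log units; within the scatter) and a 1.0-fold lower number from compound 1 to compound 4 (0.00 log units; within the scatter). Cyano therefore cannot be told apart from chloro, nitro or methyl here, and the only step beyond the scatter stays the one between chloro and nitro. Nothing available explains these steps. Going by these compounds, whether an amine or a carboxylic acid at this place would give a step clearly beyond the scatter remains open.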